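The compounds below may be only part of what the source reports. "The series", "measured", "known", "first", "only" and "open" are said of these compounds alone.

Working notes on the series, step from compound 3 to compound 4.

Of the compounds shown here, three share the core and have been read in a physicochemical assay for solubility, read by spectrophotometry, in phosphate buffer, at pH 6.5; a higher number here means a more soluble compound, a lower number a less soluble compound. Compound 1 `CS(=O)(=O)CCn1c(Cn2cc(S(C)(=O)=O)c3ccccc32)nc2cc(Cl)ccc21` gives 1 ug/mL. Compound 2 `CC(C)(O)CCn1c(Cn2nc(S(C)(=O)=O)c3ccncc32)nc2cc(Cl)ccc21` gives 41 ug/mL. Compound 3 `CC(C)(O)CCCn1c(Cn2nc(S(C)(=O)=O)c3ccncc32)nc2cc(Cl)ccc21` gives 121 ug/mL, the highest of the three numbers; the nearest is compound 2, the furthest compound 1, and both gaps lie beyond the scatter. Among the measured compounds shown here, the one step measured in one place is a 3.0-fold higher number from compound 2 to compound 3 (0.47 log units; beyond the scatter), a modest rise for moving the hydroxyl-bearing end one bond further out along the chain. Compound 1 differs from compound 3 in more than one place, so its value only shows that a far lower number occurs in the series.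

Compound 4 `CS(=O)(=O)c1nn(Cc2nc3cc(Cl)ccc3n2CCC(F)(F)F)c2cnccc12` is the next compound. The change is trifluoromethyl in place of 2-hydroxy-2-methylpropyl on a saturated chain carbon, two bonds along the chain from an aromatic nitrogen. The group that leaves carries the only hydrogen-bond donor and acceptor of the chain; what enters carries none. For the measured compounds named here, no measured step removes the hydroxyl, and the step from compound 2 to compound 3 bears on it only as a sign that this chain end moves the number. A fall beyond the scatter is expected, of about a 10-fold lower number from compound 3 to compound 4 (1.00 log units; beyond the scatter), reversing the direction of the measured step and then some. The estimate for compound 4 in this assay is 12 ug/mL, with a range from 3 ug/mL to 50 ug/mL.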

Compound 4, solubility: 3 ug/mL
For compound 4 the middle estimate is 4.0-fold (0.60 log units) above the measured one; the range from low to high includes it.
By their numbers in this assay, from the lowest: compound 1; then compound 4; then compound 2; then compound 3.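

In this assay, among the compounds shown here, this chain end proves able to carry a far larger change than the earlier compounds showed: trifluoromethyl in place of 2-hydroxy-2-methylpropyl gives a 40-fold lower number from compound 3 to compound 4 (1.61 log units; beyond the scatter), a large step set against the modest 3.0-fold higher number from compound 2 to compound 3 (0.47 log units; beyond the scatter). Trifluoromethyl in place of 1-hydroxy-1-methylethyl gives a 14-fold lower number from compound 2 to compound 4 (1.14 log units; beyond the scatter), also large, so both hydroxyl-bearing groups shown stand well above the trifluoromethyl compound at this place on the saturated chain, and the size of the fall does not depend on which of the two is replaced. Nothing measured here bears on the cause of these falls.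

Each step removes the hydroxyl-bearing group and brings in trifluoromethyl in a single change, so the compounds shown do not separate what the departure of one group contributes from what the arrival of the other contributes. A chain ending in plain isopropyl, an amine or a carboxylic acid at this place would help to divide the two, and a longer chain ending in trifluoromethyl would show whether the rise from compound 2 to compound 3 recurs without the hydroxyl.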